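Thioether series: halophenyl swap on compound 1

The compounds below may be only part of what the source reports. "The series", "measured", "known", "first", "only" and "open" are said of these compounds alone.

Compound 1 `Cn1c(=O)c2c(nc(CCSc3cccc(Br)c3)n2C)n(C)c1=O` is the weakest of the two numbered entries in an in vitro assay on cells for inhibition of Amine oxidase [flavin-containing] A (Homo sapiens), read by coupled enzyme assay, with a stated time of 20 min (a higher number here means a weaker inhibitor, a lower number a stronger inhibitor), giving 372000 nM. The nearest numbered neighbour is compound 2 `Cn1c(=O)c2c(nc(COc3cccc(Br)c3)n2C)n(C)c1=O`, which in this assay gives 34000 nM, a gap that lies beyond the scatter. Compound 3 `COc1cccc(OCc2nc3c(c(=O)n(C)c(=O)n3C)n2C)c1` gives no number in this assay, reported only as "not active" (no number reported). Compound 4 `Cn1c(=O)c2c(nc(CCSc3ccc(Cl)cc3)n2C)n(C)c1=O` has not yet been measured. Its change from compound 1 is 4-chlorophenyl in place of 3-bromophenyl on a sulfur. Going by the values given here, no step between measured compounds is available for this change, so no direction can be drawn from the data; compound 4 is expected to stay close to compound 1, with the step from compound 1 to compound 4 estimated at a 1.2-fold lower number from compound 1 to compound 4 (0.09 log units; within the scatter), not beyond the scatter. The estimated value for compound 4 in this assay is 300000 nM, within 100000 nM to 1000000 nM.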

Compound 4, half-maximal inhibitory concentration: 142000 nM
Estimate against measurement, compound 4: 2.1-fold (0.32 log units) above, and the stated range covers the measured number.
By their numbers in this assay, from the lowest: compound 2; then compound 4; then compound 1.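

In this assay, going by these compounds alone, 4-chlorophenyl in place of 3-bromophenyl on the sulfur gives a 2.6-fold lower number from compound 1 to compound 4 (0.42 log units; beyond the scatter), the first readable step. The aryl group on this sulfur therefore affects the number, but the halogen and its ring position change together, so this step cannot separate them. Nothing available bears on why the number moves. Still open, on these data alone, are 4-bromophenyl and 3-chlorophenyl on this sulfur, which would separate those two parts of the change. Also open, as far as these compounds go, is whether an amine or a carboxylic acid on this ring keeps any activity.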